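The source may report more compounds than this note shows. Statements on the series, on what has been measured and on what is new or still open speak of the compounds shown alone.

Three compounds share one core and differ only in the group carried on a sulfur. Compound 1 `CC(C)c1n[nH]c2c(NCc3ccc(-c4ccccn4)cc3)nc(SC(CO)C(C)C)nc12` carries 1-(hydroxymethyl)-2-methylpropyl there, and in a functional assay on HT cells (Homo sapiens) for antiproliferative activity, read by fluorescence, with a stated time of 72 h (on this read-out higher numbers stand for weaker inhibition of growth and lower numbers for stronger inhibition of growth), compound 1 gives 980 nM. Compound 2 `CC(C)c1n[nH]c2c(NCc3ccc(-c4ccccn4)cc3)nc(SC3CCCC3O)nc12` carries 2-hydroxycyclopentyl, and compound 2 gives 567 nM, so that a 1.7-fold lower number from compound 1 to compound 2 (0.24 log units; within the scatter). Compound 3 `CC(C)c1n[nH]c2c(NCc3ccc(-c4ccccn4)cc3)nc(SCCNC(N)=O)nc12` carries 2-ureidoethyl, and compound 3 gives 240 nM, the lowest of the three numbers: a 4.1-fold lower number from compound 1 to compound 3 (0.61 log units; beyond the scatter), and a 2.4-fold lower number from compound 2 to compound 3 (0.37 log units; beyond the scatter).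

Among the measured compounds shown here, compound 4 `CCC(CO)Sc1nc(NCc2ccc(-c3ccccn3)cc2)c2[nH]nc(C(C)C)c2n1` is the next step from compound 3. 1-(hydroxymethyl)propyl in place of 2-ureidoethyl on a sulfur The entering group is a hydroxymethyl-bearing alkyl of the same kind as that of compound 1, so the measured step that bears on this change is the one from compound 1 to compound 3, now taken in the reverse direction. Because of a 4.1-fold lower number from compound 1 to compound 3 (0.61 log units; beyond the scatter), a rise of comparable size is expected, with the change from compound 2 to compound 3 pointing the same way. Compound 4 is therefore expected to give 800 nM, within a range from 350 nM to 1800 nM. The expected step is a 3.3-fold higher number from compound 3 to compound 4 (0.52 log units; beyond the scatter).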

Compound 4, concentration for 50% growth inhibition: 255 nM
Compound 4: middle estimate off by 3.1-fold (0.50 log units), on the high side, and the stated range ends above it.
By their numbers in this assay, from the lowest: compounds 3 and 4 (each within the scatter of the next); then compounds 2 and 1 (each within the scatter of the next).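

Compound 4 shows that the 2-ureidoethyl group is not required on the sulfur for a number in this range in this assay: a 1.1-fold higher number from compound 3 to compound 4 (0.03 log units; within the scatter), even though 1-(hydroxymethyl)propyl has no nitrogen. A hydroxyl-bearing group on the sulfur therefore does not by itself go with the higher numbers of compound 1 and compound 2, as a 2.2-fold lower number from compound 2 to compound 4 (0.35 log units; beyond the scatter) shows. The sharpest result is that a single methyl on the chain separates compound 1 from compound 4, with hydrogen in its place on a saturated chain carbon bound to two saturated chain carbons, and a 3.8-fold lower number from compound 1 to compound 4 (0.58 log units; beyond the scatter).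

Nothing available explains why removing this methyl has this effect. Going by these compounds, it remains open whether a shorter chain, such as 2-hydroxyethyl, or an amine or a carboxylic acid at the end of the chain on the sulfur would stay in the range of compound 3 and compound 4.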